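Working notes: gem-dimethyl carbinol in the kinase series

This account rests on a few compounds, and the source may have more. Where it says the series, first, only, none or still open, it means among the compounds named here.

Compound 1 `Cc1cc(C(=O)O)ccc1CN1CCC[C@H](O[C@H](CO)c2cc(Cl)nc(Cl)c2)[C@@H]1c1ccccc1` and compound 2 `Cc1cc(C(=O)O)ccc1CN1CCC[C@H](OC(c2cc(Cl)cc(Cl)c2)C(C)O)[C@@H]1c1ccccc1` share one core and differ only at the side chain on the ring oxygen. In an assay on isolated protein for activation of cGMP-dependent protein kinase 1 (Homo sapiens), read by ADP-Glo, with stated times of 30 min and 2 h, in the presence of a further agent that is not named here (on this read-out higher numbers stand for an effect only at larger amounts of compound and lower numbers for an effect already at smaller amounts), compound 1 gives 2400 nM; in the same assay compound 2 gives 5300 nM. Going by the values given here, the one measured step, a 2.2-fold higher number from compound 1 to compound 2 (0.34 log units; beyond the scatter), exchanges the dichloropyridyl group for a dichlorophenyl group together with the carbinol carbon. Compound 2 thus stands highest of the two numbers seen so far.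

Compound 3 `Cc1cc(C(=O)O)ccc1CN1CCC[C@H](OC(c2cc(Cl)cc(Cl)c2)C(C)(C)O)[C@@H]1c1ccccc1` takes the next step from compound 2: methyl in place of hydrogen on a saturated chain carbon bound to an oxygen on a saturated carbon and two saturated chain carbons. Among the compounds with values here, no measured step touches this position; the step from compound 1 to compound 2 concerns the aromatic ring and gives no guidance here. With nothing to lean on, no change beyond the scatter is expected in this assay, so the expected step is no change at the digits printed from compound 2 to compound 3 (within the scatter). Compound 3 is therefore estimated at 5300 nM, within a range from 2200 nM to 13000 nM.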

Compound 3, half-maximal effective concentration: 17000 nM
Compound 3: the middle estimate sits 3.2-fold (0.51 log units) below what was measured; the whole stated range lies below it.
By their numbers in this assay, from the lowest: compound 1; then compound 2; then compound 3.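

The carbon bearing the hydroxyl is not indifferent to a small change: in this assay, going from 1-hydroxyethyl to 1-hydroxy-1-methylethyl gives a 3.2-fold higher number from compound 2 to compound 3 (0.51 log units; beyond the scatter). Going by these compounds alone, this is the first reading at this position, and a single added methyl moves the number upward, so the position responds to a change of one carbon. Nothing at hand bears on why the number rises.

The compounds shown leave open how the number responds to an ethyl in place of the added methyl, or to an amine or a methyl ether in place of the hydroxyl. Also open, from the compounds shown here alone, is whether the same added methyl gives a step of similar size and direction when the dichloropyridyl group stands in place of the dichlorophenyl group.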